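This account rests on a few compounds, and the source may have more. Where it says the series, first, only, none or still open, it means among the compounds named here.

Measured compounds:
compound 1, `O=C(/N=C(/NC(=O)c1cc(-c2ccccc2)nc2ccccc12)[Se]Cc1ccccc1)c1cc(-c2ccccc2)nc2ccccc12`: 8460 nM
compound 2, `CS/C(=N\C(=O)c1cc(-c2ccccc2)nc2ccccc12)NC(=O)c1cc(-c2ccccc2)nc2ccccc12`: 43100 nM
compound 3, `CS/C(=N\C(=O)c1cnc2ccccc2c1)NC(=O)c1cnc2ccccc2c1`: 23900 nM

In a functional assay on MCF7 cells (Homo sapiens) for cytotoxicity, read by MTT assay, with a stated time of 72 h (on this read-out higher numbers stand for weaker inhibition of growth and lower numbers for stronger inhibition of growth), compound 2 gives 43100 nM and compound 1 gives 8460 nM. The two share one core and differ only by a group of 8 heavy atoms (7 carbon, 1 selenium; one six-membered aromatic ring of carbon only) in place of a group of 2 heavy atoms (1 carbon, 1 sulfur; no ring), on a carbon with a double bond to nitrogen, and this change brought a 5.1-fold lower number from compound 2 to compound 1 (0.71 log units; beyond the scatter). Compound 3 carries the same methylsulfanyl group as compound 2 on a different core; the difference between the two cores is not broken down here. In this assay compound 3 gives 23900 nM, a number that lies within the scatter of the value of compound 2, so no order between those two can be drawn.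

Compound 4, `O=C(/N=C(/NC(=O)c1cnc2ccccc2c1)[Se]Cc1ccccc1)c1cnc2ccccc2c1`, has not yet been measured. It stands to compound 3 as compound 1 stands to compound 2: it carries a group of 8 heavy atoms (7 carbon, 1 selenium; one six-membered aromatic ring of carbon only) in place of a group of 2 heavy atoms (1 carbon, 1 sulfur; no ring), on a carbon with a double bond to nitrogen, the same change at the same place. Since the two cores gave values within the scatter of each other with the methylsulfanyl group in place, it is expected that this change gives a step of about the size seen before, a 4.3-fold lower number from compound 3 to compound 4 (0.64 log units; beyond the scatter), resting on the step of a 5.1-fold lower number from compound 2 to compound 1 (0.71 log units; beyond the scatter). Compound 4 is therefore estimated at 5500 nM in this assay, with a range from 2000 nM to 15000 nM.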

Compound 4, concentration for 50% growth inhibition: 23600 nM
Compound 4: the middle estimate sits 4.3-fold (0.63 log units) below what was measured; measured number above the stated range.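

In this assay, replacing the methylsulfanyl group with the selenium-bearing group of 8 heavy atoms gave a 1.0-fold lower number from compound 3 to compound 4 (0.01 log units; within the scatter), so no effect of this change can be read on this core. The change therefore did not carry over from one core to the other with the same size: the same change on two cores in this assay, a 5.1-fold lower number (0.71 log units; beyond the scatter) from compound 2 to compound 1 and a 1.0-fold lower number (0.01 log units; within the scatter) from compound 3 to compound 4, 5.0-fold (0.70 log units) apart, beyond the scatter of two such steps The two pairs show only that, in this assay, the step seen on one core could not be relied on for the other; they do not show which feature of the cores goes with the difference, nor do they give a rule for any further core.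

The compounds shown leave open whether the lower number of compound 1 goes with the selenium or with the aromatic ring, as the two enter together, and a methylselanyl or a benzylsulfanyl group would separate them. They also leave open how an amine or a longer alkyl chain at the same place would behave on either core.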